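This account rests on a few compounds, and the source may have more. Where it says the series, first, only, none or still open, it means among the compounds named here.

For the measured compounds named here, compound 3 `Cc1ccc(Oc2ccc3nc(COc4cccc(C(=O)O)c4)n(C)c3c2)nc1C` stands highest of the three numbers so far in a physicochemical assay for solubility, read by HPLC, measured as thermodynamic solubility, with a stated time of 4 h, at pH 6.8; a higher number here means a more soluble compound, a lower number a less soluble compound: compound 3 gives 190 ug/mL, whereas compound 1 `Cn1c(COc2cccc(C(=O)O)c2)nc2ccc(Oc3ccccn3)cc21` gives 62 ug/mL and compound 2 `Cn1c(COc2cccc(C(=O)O)c2)nc2ccc(Oc3ccc(Cl)cn3)cc21` gives 17 ug/mL. The steps behind these numbers are a 3.1-fold higher number from compound 1 to compound 3 (0.49 log units; beyond the scatter), an 11-fold higher number from compound 2 to compound 3 (1.05 log units; beyond the scatter) and a 3.6-fold lower number from compound 1 to compound 2 (0.56 log units; beyond the scatter).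

Compound 4 `Cc1cc(Cl)cnc1Oc1ccc2nc(COc3cccc(C(=O)O)c3)n(C)c2c1` differs from compound 3 in one place: 5-chloro-3-methylpyridin-2-yl in place of 5,6-dimethylpyridin-2-yl on an oxygen on an aromatic ring. The change takes away one of the two methyl groups and brings in a chloro, so two measured steps bear on it. The chloro step from compound 1 to compound 2 went down by a modest amount, and the dimethyl step from compound 1 to compound 3 went up by a modest amount; compound 4 keeps only one methyl and adds the chloro, so a drop from compound 3 is expected, of roughly the size seen in those two steps. The expected step is a 3.5-fold lower number from compound 3 to compound 4 (0.54 log units; beyond the scatter). In this assay compound 4 is estimated at 55 ug/mL, with a range of 20 ug/mL to 150 ug/mL.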

Compound 4, solubility: 3.9 ug/mL
For compound 4 the middle estimate is 14-fold (1.15 log units) above the measured one; the measured number lies below the stated range.
By their numbers in this assay, from the lowest: compound 4; then compound 2; then compound 1; then compound 3.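

In this assay a methyl on an aromatic carbon does not move the number one way across this series: the added methyl on the 5-chloropyridin-2-yl group lowers it (a 4.4-fold lower number from compound 2 to compound 4 (0.64 log units; beyond the scatter)), whereas 5,6-dimethylpyridin-2-yl in place of pyridin-2-yl raises it (a 3.1-fold higher number from compound 1 to compound 3 (0.49 log units; beyond the scatter)). The same 5-chloro-3-methylpyridin-2-yl group on the oxygen gives large drops against both dimethyl and unsubstituted partners (a 49-fold lower number from compound 3 to compound 4 (1.69 log units; beyond the scatter)) (a 16-fold lower number from compound 1 to compound 4 (1.20 log units; beyond the scatter)), which places compound 4 lowest of the four. No measurement at hand accounts for these steps.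

Going by these compounds, whether a methyl on the pyridin-2-yl group without the chloro also lowers the number remains open. So does the outcome of an amine or a methoxy in place of the chloro of compound 4.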